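The compounds below may be only part of what the source reports. "The series", "measured", "known", "first", "only" and "open" are said of these compounds alone.

Working notes on the series. In a functional assay on A-375 cells (Homo sapiens) for antiproliferative activity, read by trypan blue exclusion, with a stated time of 48 h, tested at 5 uM (on this read-out lower numbers stand for a stronger effect and higher numbers for a weaker effect at the one concentration tested), compound 1 `CC(=O)Nc1nc(-c2cccc(NS(=O)(=O)c3ccc(Br)cc3)c2)cs1` gives 19.7%. Compound 2 `CC(=O)Nc1nc(-c2cccc(NS(=O)(=O)c3ccc(C#CCO)cc3)c2)cs1` gives 99.3% and compound 3 `CC(=O)Nc1nc(-c2cccc(NS(=O)(=O)c3ccc(C#CCCc4ccccc4)cc3)c2)cs1` gives 4.2% in this assay. Compound 1 thus stands second highest of the three numbers: the step of a number 79.6 percentage points higher from compound 1 to compound 2 (beyond the scatter) is large and goes toward a weaker effect, while the step of a number 15.5 percentage points lower from compound 1 to compound 3 (beyond the scatter) is modest and goes toward a stronger effect. The step of a number 95.1 percentage points lower from compound 2 to compound 3 (beyond the scatter) shows how far the two alkynyl compounds lie apart.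

Compound 4 `C#Cc1cccc(S(=O)(=O)Nc2cccc(-c3csc(NC(C)=O)n3)c2)c1` is not yet measured. It differs from compound 1 in one place: 3-ethynylphenyl in place of 4-bromophenyl on a sulfonyl sulfur. Both measured steps from compound 1 bear on this change, since each of them too puts a triple-bonded carbon on the sulfonyl-bound ring in place of bromo, yet they pull in opposite directions and with very different size. Here the triple bond carries nothing further and the ring is substituted at a different position, so neither step can be carried over directly. A step in this assay of uncertain direction, lying between the two measured ones, is the expectation, that is a number 20.3 percentage points higher from compound 1 to compound 4 (beyond the scatter). On that basis compound 4 is estimated at 40%, within the range 8% to 85%.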

Compound 4, a percentage reported as activity, at one concentration (the size of the read-out at that concentration, not a potency): 29%
Compound 4: middle estimate off by 11 percentage points, on the high side, and the stated range covers the measured number.
By their numbers in this assay, from the lowest: compound 3; then compounds 1 and 4 (each within the scatter of the next); then compound 2.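

In this assay, among the compounds shown here, the step of a number 9.3 percentage points higher from compound 1 to compound 4 (within the scatter) is the first replacement on the sulfonyl sulfur that leaves the number within the scatter, whereas both earlier steps from compound 1 moved it beyond the scatter. This position therefore accepts 3-ethynylphenyl in place of 4-bromophenyl without a readable change at the one concentration tested, so the bromine of compound 1 is not required to hold this level of effect, and a triple bond on this ring does not by itself bring the loss seen with compound 2. No measurement at hand accounts for this outcome or for the spread among the alkynyl compounds.

Since compound 4 changes both the substituent and its place on the ring, the compounds shown cannot separate these two changes, and 3-bromophenyl or 4-ethynylphenyl on the sulfonyl sulfur would be needed to tell them apart. As far as these compounds go, it also remains open how a chain on the triple bond behaves when it ends in an amine or a carboxylic acid instead of the hydroxy of compound 2 or the phenyl of compound 3.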